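This account rests on a few compounds, and the source may have more. Where it says the series, first, only, none or still open, it means among the compounds named here.

Going by the values given here, compound 1, `COc1cc2c(cc1OC)C(CC(=O)NC(C)C)CC2`, is the stronger-looking of the two compounds measured so far in a functional assay on the whole organism (strain Wistar) for inhibition, with Rattus norvegicus as the target, read by paw edema, with stated times of 60 min and 6 h, at a dose of 100 mg/kg by the oral route (a lower number here means less inhibition, a higher number more inhibition at the dose given (going by the name of the read-out)), where compound 1 gives 37%. Its nearest neighbour, compound 2, `COc1cc2c(cc1OC)C(CC(=O)N1CCNCC1)CC2`, gives 33.3% in this assay; the step of a number 3.7 percentage points lower from compound 1 to compound 2 (within the scatter) is one that a repeat of either measurement could easily erase, so the two compounds are best described as alike on this read-out.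

Compound 3, `COc1cc2c(cc1OC)C(CC(=O)N1CCOCC1)CC2`, is not yet measured. It differs from compound 1 in a single place: morpholin-4-yl in place of isopropylamino on a carbonyl carbon. Among the compounds with values here, only one measured step bears on this change, the one from compound 1 to compound 2, in which the same isopropylamino on the carbonyl carbon gave way to a six-membered saturated ring, and that step stayed within the scatter, a number 3.7 percentage points lower from compound 1 to compound 2 (within the scatter). On that evidence the account expects no step beyond the scatter in this assay for compound 3 either, a number 4 percentage points lower from compound 1 to compound 3 (within the scatter). Compound 3 is therefore estimated at 33%, with a range from 20% to 47%.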

Compound 3, a percentage reported as inhibition, in the whole organism at one dose (the size of the read-out at that dose, not a potency): 14.8%
Compound 3: the middle estimate sits 18.2 percentage points above what was measured; the measured number lies below the stated range.
By their numbers in this assay, from the lowest: compound 3; then compounds 2 and 1 (each within the scatter of the next).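

In this assay, the place on the carbonyl carbon turns out to tell one six-membered ring from another: morpholin-4-yl in place of piperazin-1-yl gives a number 18.5 percentage points lower from compound 2 to compound 3 (beyond the scatter). Morpholin-4-yl in place of isopropylamino likewise gives a number 22.2 percentage points lower from compound 1 to compound 3 (beyond the scatter), whereas piperazin-1-yl and isopropylamino stand within the scatter of each other, so a ring at this place does not by itself go with the lower number, and compound 2 is the case against any such rule. Nothing at hand gives a reason for the gap between the two rings.

The compounds shown leave open where piperidin-1-yl, whose ring holds no second hetero atom, would fall, and whether 4-methylpiperazin-1-yl would stay with piperazin-1-yl or drop towards morpholin-4-yl. They also leave open whether a smaller open-chain amine such as dimethylamino, or a longer chain on the amide nitrogen, would hold the level of isopropylamino, and all of this rests on a single dose, which gives the size of the read-out and not a potency.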